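Nitro for Chloro: Expecting Another Assay Limit

This account rests on a few compounds, and the source may have more. Where it says the series, first, only, none or still open, it means among the compounds named here.

Compound 1, `O=S(=O)(Nc1ccc2oc(-c3ccccc3)nc2c1)c1ccccc1O`: in an assay on isolated protein for inhibition of malate dehydrogenase, mitochondrial (Sus scrofa), with stated times of 45 min and 30 min (on this read-out lower numbers stand for stronger inhibition and higher numbers for weaker inhibition), compound 1 gives only a limit, > 63000 nM.
Compound 2, `O=S(=O)(Nc1ccc2oc(-c3ccccc3)nc2c1)c1ccc(Cl)c(Cl)c1`: in this assay compound 2 gives only a limit, > 63000 nM.
Compound 3, `Cc1cccc(S(=O)(=O)Nc2ccc3oc(-c4ccccc4)nc3c2)c1`: in this assay compound 3 gives only a limit, > 63000 nM.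

Compound 2 stands at the assay limit, a mark it shares with both other measured compounds because of the limit of > 63000 nM in this assay, at which 3 of the 3 values shown sit. Compound 4, `O=[N+]([O-])c1cc(S(=O)(=O)Nc2ccc3oc(-c4ccccc4)nc3c2)ccc1Cl`, differs from compound 2 by nitro in place of chloro on an aromatic carbon. The measured steps a step that the two limits leave unreadable from compound 1 to compound 2, a step that the two limits leave unreadable from compound 1 to compound 3 and a step that the two limits leave unreadable from compound 2 to compound 3 all run between two limits, so none has a readable size and none points in a direction. With no readable step to build on, compound 4 is expected to give only a limit again, estimated at 63000 nM within a range from 20000 nM to 200000 nM. That estimate means an expected step of a number no higher from compound 2 to compound 4 (the limit leaves the size open), which is no change beyond the scatter.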

Compound 4, half-maximal inhibitory concentration: > 63000 nM
Compound 4 was reported as a limit; the forecaster's own chance of this, stated with the estimate: 80%; the middle value sits exactly at the limit.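

Compound 4, like compound 2, gives only a limit, so the step between them cannot be read: the limit of > 63000 nM in this assay, at which 4 of the 4 values shown sit. The compounds shown leave open whether any other group in these places would give a readable number instead of a limit.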